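The source may hold more compounds than are shown below. What is called first, only, known or untested is meant among the compounds shown, and "the series" means these compounds.

Measured so far in a functional assay on HOP-92 cells (Homo sapiens) for inhibition, read by sulforhodamine B assay, with a stated time of 48 h; on this read-out higher numbers stand for weaker inhibition of growth and lower numbers for stronger inhibition of growth:
- compound 1 `Cc1ccc(C2=NN(c3ccc(S(C)(=O)=O)cc3)C(=O)CC2)cc1` gives 8300 nM
- compound 2 `Cc1cc(O)ccc1C1=NN(c2ccc(S(C)(=O)=O)cc2)C(=O)CC1` gives > 100000 nM (a limit, not a number)

Compound 2 sits at the limit of > 100000 nM in this assay, at which 1 of the 2 values shown sits, and has no exact value. The next change leads to compound 3 `CCc1ccc(C2=NN(c3ccc(S(C)(=O)=O)cc3)C(=O)CC2)cc1` and is 4-ethylphenyl in place of 4-hydroxy-2-methylphenyl on a carbon with a double bond to nitrogen in the same place on the core, with 4-ethylphenyl in place of 4-hydroxy-2-methylphenyl. Among the compounds with values here, one measured step bears on this: an at least 12-fold higher number from compound 1 to compound 2 (1.08 log units; beyond the scatter) is large and introduced the same 4-hydroxy-2-methylphenyl group that now leaves. Within the data shown here, no measured step covers 4-ethylphenyl itself, so 4-methylphenyl in compound 1 at 8300 nM is the nearest guide. A large move towards stronger inhibition of growth is therefore expected, with an estimated size of an at least 11-fold lower number from compound 2 to compound 3 (1.04 log units; beyond the scatter) on this read-out. For compound 3 the estimate is 9000 nM with 3500 nM to 25000 nM as the expected range.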

Compound 3, concentration for total growth inhibition: 9880 nM
Estimate against measurement, compound 3: 1.1-fold (0.04 log units) below; measured number inside the range.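

In this assay, the added methyl on the saturated chain carbon bound to an aromatic carbon gives a 1.2-fold higher number from compound 1 to compound 3 (0.08 log units; within the scatter), so 4-methylphenyl and 4-ethylphenyl cannot be told apart at this place on the core. Within the data shown here, with 4-ethylphenyl in place of 4-hydroxy-2-methylphenyl the result is an at least 10-fold lower number from compound 2 to compound 3 (1.00 log units; beyond the scatter), which leaves 4-hydroxy-2-methylphenyl as the one group of the three that stands apart. The size of that step has only a lower bound, as compound 2 carries a limit and not a number: the limit of > 100000 nM in this assay, at which 1 of the 3 values shown sits.

Compound 2 differs from compound 1 in both a hydroxy group and a ring methyl, and the compounds shown do not separate the two. Also open, as far as these compounds go, is how far this place accepts a longer chain such as 4-butylphenyl, or an amine such as 4-aminophenyl.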